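The source may report more compounds than this note shows. Statements on the series, on what has been measured and on what is new or still open speak of the compounds shown alone.

Working notes on the shared core, varied at the aryl ether end. Compound 1 `CC1(COc2ccc(OC(F)(F)F)cc2)Cn2cc([N+](=O)[O-])nc2O1`, compound 2 `CC1(COc2ccc(C(F)(F)F)cc2)Cn2cc([N+](=O)[O-])nc2O1` and compound 3 `CC1(COc2ccc(-c3ccc(C(F)(F)F)cc3)cc2)Cn2cc([N+](=O)[O-])nc2O1` have been measured in an ADME assay on MRC5 cells (Homo sapiens) for cytotoxicity, read by fluorescence, with a stated time of 72 h; a lower number here means a stronger inhibitor, a higher number a weaker inhibitor; compound 4 `CC1(COc2ccc(-c3ccc(OC(F)(F)F)cc3)cc2)Cn2cc([N+](=O)[O-])nc2O1` has not. In this assay compound 1 gives only a limit, > 64000 nM. Compound 2 likewise gives only a limit, > 64000 nM. Compound 3 also gives only a limit, > 64000 nM. The steps a step that the two limits leave unreadable from compound 2 to compound 1, a step that the two limits leave unreadable from compound 1 to compound 3 and a step that the two limits leave unreadable from compound 2 to compound 3 stay unreadable because of the limit of > 64000 nM in this assay, at which 3 of the 3 values shown sit. Compound 4 differs from compound 3 by trifluoromethoxy in place of trifluoromethyl on an aromatic carbon; the same change stands between compound 2 and compound 1, (trifluoromethoxy in place of trifluoromethyl on an aromatic carbon), where a step that the two limits leave unreadable from compound 2 to compound 1 could not be sized. The cores of compound 3 and compound 2 differ by 4-(trifluoromethyl)phenyl in place of trifluoromethyl on an aromatic carbon. For compound 4 the step that the limit leaves unreadable from compound 3 to compound 4 is expected, resting on the fact that every measured value here sits at the limit of > 64000 nM in this assay, at which 3 of the 3 values shown sit. Compound 4 is therefore estimated at 80000 nM, expected between 40000 nM and 200000 nM, most likely reported only as a limit.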

Compound 4, half-maximal inhibitory concentration: > 64000 nM
Compound 4 gave a limit, no number (the forecaster's own chance of this, stated with the estimate: 85%); the middle value does not contradict the limit.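

No step between compound 3 and compound 4 can be read, because both give only a limit: the limit of > 64000 nM in this assay, at which 4 of the 4 values shown sit.

The compounds shown leave open whether trifluoromethoxy in place of trifluoromethyl shifts the half-maximal inhibitory concentration in this assay at all.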